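The source may report more compounds than this note shows. Statements on the series, on what has been measured and on what is new or still open speak of the compounds shown alone.

Going by the values given here, compound 2 `COc1cc2c(Nc3nc4ccc(C(=O)Nc5c(C)cc(C)cc5C)cc4s3)ncnc2cc1OCCCN1CCCCC1C` stands lowest of the two numbers so far in a functional assay on HCT-116 cells (Homo sapiens) for cytotoxicity, read by WST assay, with a stated time of 72 h (a higher number here means a weaker inhibitor, a lower number a stronger inhibitor), where compound 2 gives 5600 nM; its nearest neighbour, compound 1 `COc1cc2c(Nc3nc4ccc(C(=O)Nc5c(C)cccc5Cl)cc4s3)ncnc2cc1OCCCN1CCCCC1C`, gives 7200 nM, and the step of a 1.3-fold lower number from compound 1 to compound 2 (0.11 log units; within the scatter) lies within the scatter. Compound 3 `COc1cc2c(Nc3nc4ccc(C(=O)Nc5c(C)cc(C)cc5C)cc4s3)ncnc2cc1OCCCN1CCCC1` differs from compound 2 by pyrrolidin-1-yl in place of 2-methylpiperidin-1-yl on a saturated chain carbon, three bonds along the chain from an oxygen on an aromatic ring. Among the compounds with values here, no measured step touches this chain amine; the only step on record, a 1.3-fold lower number from compound 1 to compound 2 (0.11 log units; within the scatter), concerns the amide aryl group and was within the scatter. No step beyond the scatter is therefore expected, so no change at the digits printed from compound 2 to compound 3 (within the scatter) is the estimate. Compound 3 is expected at 5600 nM, range 2500 nM to 12500 nM.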

Compound 3, half-maximal inhibitory concentration: 5800 nM
Estimate against measurement, compound 3: 1.0-fold (0.02 log units) below; low and high end bracket the measured number.
By their numbers in this assay, from the lowest: compounds 2, 3 and 1 (each within the scatter of the next).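

In this assay, going by these compounds alone, the first change at the chain amine, 3-(pyrrolidin-1-yl)propyl in place of 3-(2-methylpiperidin-1-yl)propyl, gives a 1.0-fold higher number from compound 2 to compound 3 (0.02 log units; within the scatter). With the 2,4,6-trimethylphenyl amide held fixed, this assay does not separate the five-membered ring from the six-membered ring carrying a methyl group. Nothing on hand bears on why the two read alike.

Open, on these data alone, is whether a morpholine or a dimethylamino group at this chain end would read differently. As far as these compounds go, a shorter or longer chain carrying the pyrrolidin-1-yl group is equally open.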